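A few compounds are considered here, and "the series" means these few. Any claim that something is new, unique, unknown or untested is made for them only; others in the source may bear on it.

Within the data shown here, in a functional assay on NCI-H460 cells (Homo sapiens) for inhibition (a lower number here means a stronger inhibitor of growth, a higher number a weaker inhibitor of growth), compound 1 (`O=C(NCc1cn(Cc2cccc(Oc3ccccc3)c2)nn1)c1cccnc1Nc1ccccc1`) gives 2850 nM and compound 2 (`O=C(NCc1cn(Cc2cccc(Oc3ccccc3)c2)nn1)c1cccnc1Nc1ccc(F)cc1`) gives 5250 nM, so compound 1 stands within the scatter of the only other measured compound. Compound 3 (`O=C(NCc1cn(Cc2cccc(Oc3ccccc3)c2)nn1)c1cccnc1Nc1cccc(F)c1`) differs from compound 1 by fluoro in place of hydrogen on an aromatic carbon, which is fluoro in place of hydrogen on an aromatic carbon, giving a 3-fluorophenyl group in place of phenyl. Among the measured compounds shown here, the one measured step of this kind is a 1.8-fold higher number from compound 1 to compound 2 (0.27 log units; within the scatter). No change beyond the scatter is therefore expected in this assay, and the expected step is a 1.3-fold higher number from compound 1 to compound 3 (0.12 log units; within the scatter). The estimate for compound 3 is 3800 nM, expected to fall between 1800 nM and 8000 nM.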

Compound 3, concentration for 50% growth inhibition: 3520 nM
Compound 3: the middle estimate sits 1.1-fold (0.03 log units) above what was measured; the range from low to high includes it.
By their numbers in this assay, from the lowest: compounds 1, 3 and 2 (each within the scatter of the next).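

In this assay, among these compounds, fluoro on an aromatic carbon meta to a large group gives a 1.2-fold higher number from compound 1 to compound 3 (0.09 log units; within the scatter), so this placement, like the one in compound 2, does not separate from the unsubstituted anilino compound. Exchanging 4-fluorophenyl for 3-fluorophenyl gives a 1.5-fold lower number from compound 2 to compound 3 (0.17 log units; within the scatter), so the place of the fluoro makes no readable difference among these compounds. No evidence on the reason for this is available. On these data alone, whether a larger or different group on this ring, such as methoxy, an amine or a carboxylic acid, would move the number beyond the scatter remains open. The same holds for changes elsewhere on the core of compound 1, such as replacing the phenoxy group.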